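A few compounds are considered here, and "the series" means these few. Any claim that something is new, unique, unknown or untested is made for them only; others in the source may bear on it.

Of the compounds shown here, two of one shared core have been measured so far. In an assay on isolated protein for inhibition of Amine oxidase [flavin-containing] A (Homo sapiens), read by fluorescence and Amplex Red, with a stated time of 30 min, tested at 100 uM (on this read-out higher numbers stand for a stronger effect at the one concentration tested and lower numbers for a weaker effect), compound 2 `COCCNc1nnc(SCC(=O)N(Cc2cccc([N+](=O)[O-])c2)c2ccc(F)cc2)s1` gives 91.6%, and compound 1 `CC(C)CNc1nnc(SCC(=O)N(Cc2cccc([N+](=O)[O-])c2)c2ccc(F)cc2)s1` gives 84.3%, two numbers the scatter does not separate; the step of a number 7.3 percentage points higher from compound 1 to compound 2 (within the scatter) exchanged one chain for another on the same nitrogen. Compound 3 `CC(C)Nc1nnc(SCC(=O)N(Cc2cccc([N+](=O)[O-])c2)c2ccc(F)cc2)s1` now differs from compound 2 by isopropyl in place of 2-methoxyethyl on a nitrogen on an aromatic ring. For the measured compounds named here, since the one comparable step at that nitrogen stayed within the scatter, compound 3 is expected to give a number close to compound 2, with the step of a number 5.6 percentage points lower from compound 2 to compound 3 (within the scatter) expected to be small. Compound 3 is therefore estimated at 86%, between 72% and 96%.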

Compound 3, a percentage reported as inhibition, at one concentration (the size of the read-out at that concentration, not a potency): 89.1%
Beside the measured number, compound 3's estimate is 3.1 percentage points below it; the measured number falls inside the stated range.
By their numbers in this assay, from the lowest: compounds 1, 3 and 2 (each within the scatter of the next).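

With isopropyl on the nitrogen, this assay gives a number 2.5 percentage points lower from compound 2 to compound 3 (within the scatter) and a number 4.8 percentage points higher from compound 1 to compound 3 (within the scatter). Compound 3 therefore adds a third chain at this nitrogen, and its isopropyl carries no hydrogen-bond acceptor where the 2-methoxyethyl of compound 2 carries one, yet the scatter separates none of the three compounds. Nothing available explains this result. On these data alone, what stays open is whether a chain ending in a carboxylic acid or an amine, or a phenyl ring, on this nitrogen would give a step beyond the scatter.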